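Swapping a Phenyl for an Amide Arm on a Weak Inhibitor

The source may report more compounds than this note shows. Statements on the series, on what has been measured and on what is new or still open speak of the compounds shown alone.

Measured so far in a functional assay on DU-145 cells (Homo sapiens) for inhibition, read by MTT assay, with a stated time of 24 h; on this read-out higher numbers stand for weaker inhibition and lower numbers for stronger inhibition:
compound 1 `CCOC(=O)C1=Cc2ccccc2OC1(OCc1cn(-c2ccccc2)nn1)C(F)(F)F`: > 150000 nM
compound 2 `COc1ccc(-c2cc(COC3(C(F)(F)F)Oc4ccccc4C=C3C(=O)O)on2)cc1`: 42000 nM

In this assay compound 1 gives > 150000 nM. That value is a limit of the assay and not a number, as the limit of > 150000 nM in this assay, at which 1 of the 2 values shown sits, shows. In this assay compound 2 gives 42000 nM, a weak inhibition but one with a measured number.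

Compound 3 `CCOC(=O)C1=Cc2ccccc2OC1(OCc1cn(CC(=O)Nc2ccc(OC)cc2)nn1)C(F)(F)F` is the next to be measured. It differs from compound 1 in one place: ((4-methoxyphenyl)carbamoyl)methyl in place of phenyl on an aromatic nitrogen. Among the measured compounds shown here, no two measured compounds differ in just one place, so no measured step exists from which the size of this change could be read off, and the starting point, compound 1, is itself only a limit rather than a fixed number. The expectation is therefore cautious. The step of an at least 1.2-fold lower number from compound 1 to compound 3 (0.09 log units; that floor lies within the scatter) is expected to lean toward stronger inhibition but to stay within or near the usual scatter. For compound 3 in this assay the estimate is 120000 nM, within a range from 40000 nM to 300000 nM, with a real chance that only a limit is reported again.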

Compound 3, half-maximal inhibitory concentration: 32700 nM
Estimate against measurement, compound 3: 3.7-fold (0.56 log units) above, outside the stated range (below it).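

The aromatic nitrogen of the five-membered ring with 3 nitrogen turns out to be a position where a single change registers in this assay: putting ((4-methoxyphenyl)carbamoyl)methyl in place of phenyl gives an at least 4.5-fold lower number from compound 1 to compound 3 (0.66 log units; beyond the scatter). Among the compounds shown here, this is the first one-place comparison, and it shows that the group on this nitrogen can move the read-out beyond the usual scatter while the rest of compound 1 stays the same. The step is only a floor and its true size could be larger, because compound 1 has a limit and not a number: the limit of > 150000 nM in this assay, at which 1 of the 3 values shown sits.

The entering arm differs from phenyl in several ways at once, bringing a carbonyl, the amide hydrogen and a methoxy group together, so the compounds shown cannot say which of these parts accounts for the step. Going by these compounds, it also stays open whether an arm ending in an amine or a carboxylic acid, or a longer chain within the arm, would push the inhibition further, hold it or lose it.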